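Swapping an aminoamino group for methylsulfanyl on a shared core

The source may report more compounds than this note shows. Statements on the series, on what has been measured and on what is new or still open speak of the compounds shown alone.

Compound 1 `CN(C)c1ccc(-c2nc(NN)n(C)c(=O)c2C#N)cc1`: in a functional assay, with a stated time of 150 min (a higher number here means a weaker inhibitor, a lower number a stronger inhibitor), compound 1 gives 69 ug/mL.
Compound 2 `Cn1c(NN)nc(-c2cccc(O)c2O)c(C#N)c1=O`: in this assay compound 2 gives 44 ug/mL.
Compound 3 `CSc1nc(-c2cccc(O)c2O)c(C#N)c(=O)n1C`: in this assay compound 3 gives 53 ug/mL.

The three numbers sit close together, and none of the gaps between them is large enough to call one compound stronger or weaker than another. Compound 2 and compound 3 differ in one place: methylsulfanyl in place of aminoamino on an aromatic carbon. That step gave a 1.2-fold higher number from compound 2 to compound 3 (0.08 log units; within the scatter), too small a shift to read as a real change.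

Compound 4 `CSc1nc(-c2ccc(N(C)C)cc2)c(C#N)c(=O)n1C` has not yet been measured. It relates to compound 1 the way compound 3 relates to compound 2: methylsulfanyl in place of aminoamino on an aromatic carbon. The surroundings are not identical, though: in compound 1 the carbon is meta to a group of 9 heavy atoms, whereas in compound 2 it is meta to a group of 8 heavy atoms, so this is the same kind of change rather than the same change. How the core of compound 1 differs from the core of compound 2 is not broken down here.

In this assay the step is expected to be small, about a 1.2-fold higher number from compound 1 to compound 4 (0.06 log units; within the scatter), because the matching step gave a 1.2-fold higher number from compound 2 to compound 3 (0.08 log units; within the scatter). Compound 4 is therefore estimated at 80 ug/mL, with a likely range from 45 ug/mL to 140 ug/mL.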

Compound 4, half-maximal inhibitory concentration: 93 ug/mL
The estimate for compound 4 lay 1.2-fold (0.07 log units) below the measured number; the measured number falls inside the stated range.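

On the core of compound 1, putting methylsulfanyl in place of aminoamino hardly moves the result in this assay, with a step of a 1.3-fold higher number from compound 1 to compound 4 (0.13 log units; within the scatter). Set beside the same change on the other core, the two steps agree: the same change on two cores in this assay, a 1.2-fold higher number (0.08 log units; within the scatter) from compound 2 to compound 3 and a 1.3-fold higher number (0.13 log units; within the scatter) from compound 1 to compound 4, 1.1-fold (0.05 log units) apart, within the scatter of two such steps. This shows that, on these two cores, the swap leaves the number where it was within the scatter, but two pairs cannot establish a rule for the series, and since neither step is a real shift, the agreement shows only that a lack of effect carried over, not that a measurable effect would.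

The compounds shown leave open whether anything placed on this carbon would move the number, for instance a simple amine, a longer chain ending in sulfur, or a carboxylic acid. They also leave open whether the swap would stay this quiet on a core carrying another group in place of the cyano group.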